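This account rests on a few compounds, and the source may have more. Where it says the series, first, only, none or still open, it means among the compounds named here.

Compound 3 `CC(C)N(Cc1cccc(OCCCCCC(=O)O)c1)C(=O)c1ccc(-c2ccoc2)cc1` belongs to a small set of three tested relatives that share one core and are compared in an ADME assay on BJ cells (Homo sapiens) for cytotoxicity, read by CellTiter-Glo and resazurin assay, with a stated time of 72 h; a higher number here means that more compound is needed for the effect, a lower number that less compound is needed. For compound 3 the result is a limit, > 26000 nM. Compound 1 `CC(C)N(Cc1cccc(OCCCCCC(=O)O)c1)C(=O)c1ccccc1` likewise reaches only a limit, and compound 1 gives > 26000 nM. Compound 2 `CC(C)N(Cc1cccc(OCCCCCC(=O)O)c1)C(=O)c1ccc(-c2cccc3ccccc23)cc1` sits at the opposite limit, where compound 2 gives < 1.3 nM. Compound 4 `CC(C)N(Cc1cccc(OCCCCCC(=O)O)c1)C(=O)c1ccc(-c2ccc3c(c2)OCCO3)cc1` has not been tested; it differs from compound 3 in one place: 2,3-dihydro-1,4-benzodioxin-6-yl in place of furan-3-yl on an aromatic carbon. The measured steps at this position are large or unreadable: an at least 20000-fold lower number from compound 1 to compound 2 (4.30 log units; beyond the scatter), an at least 20000-fold higher number from compound 2 to compound 3 (4.30 log units; beyond the scatter), and a step that the two limits leave unreadable from compound 1 to compound 3. The entering group, with its two fused rings, is closer in size to naphthalen-1-yl than to furan-3-yl, yet only compound 2 has shown a low number, so a clear lowering is uncertain. The expected step for compound 4 is an at least 8.6-fold lower number from compound 3 to compound 4 (0.93 log units; beyond the scatter) in this assay, a lowering with wide uncertainty. Compound 4 is therefore estimated at 3000 nM, within 150 nM to 26000 nM.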

Compound 4, half-maximal effective concentration: > 21900 nM
Compound 4: only a limit was reported; the forecaster's own chance of this, stated with the estimate: 35%; middle value at least 7.3-fold (0.86 log units) away from the limit.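

In this assay compound 4 gives > 21900 nM, which is a limit and not a number. Putting 2,3-dihydro-1,4-benzodioxin-6-yl in place of naphthalen-1-yl gives an at least 16000-fold higher number from compound 2 to compound 4 (4.22 log units; beyond the scatter), so among the compounds shown, having two fused rings at this position is not enough to bring the low number, and compound 2 remains the only compound with one. The steps to compound 4 from compound 1 and from compound 3 cannot be read, as both ends of each step are limits.

As far as these compounds go, it remains open whether naphthalen-2-yl or a plain phenyl ring on the same aromatic carbon would give a low number. Also open, from the compounds shown here alone, is how far the true values of compound 1, compound 3 and compound 4 lie beyond their limits.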